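The source may report more compounds than this note shows. Statements on the series, on what has been measured and on what is new or still open speak of the compounds shown alone.

The measured compounds are compound 1 `COC(=O)c1cc(-c2cccc(NC(=O)c3ccc(/C=C/C(=O)c4ccccc4Br)cc3)c2)on1` and compound 2 `COC(=O)c1cc(-c2cccc(NC(=O)c3ccc(/C=C/C(=O)c4ccccc4C)cc3)c2)on1`. In an ADME assay on Vero cells (Chlorocebus sabaeus) for cytotoxicity, read by MTT assay, with a stated time of 72 h (a lower number here means that less compound is tolerated, a higher number that more compound is tolerated), compound 1 gives > 40 ug/mL, which is a limit of the assay rather than a number. In this assay compound 2 gives > 25 ug/mL, again a limit. Going by the values given here, compound 2 thus stands only at a limit (the limit of > 25 ug/mL in this assay, at which 1 of the 2 values shown sits), and the one other value in this assay is likewise a limit (the limit of > 40 ug/mL in this assay, at which 1 of the 2 values shown sits). The step that the two limits leave unreadable from compound 1 to compound 2 cannot be sized from two limits. Compound 3 `COC(=O)c1cc(-c2cccc(NC(=O)c3ccc(/C=C/C(=O)c4ccc(OC)c([N+](=O)[O-])c4)cc3)c2)on1` carries 4-methoxy-3-nitrophenyl in place of 2-methylphenyl on a carbonyl carbon. Among the compounds with values here, no measured step covers this change, and the only step available is unreadable, so the expectation for this assay rests on the limits alone: no step beyond the scatter is expected, a step that the limit leaves unreadable from compound 2 to compound 3. Compound 3 is estimated at 35 ug/mL, between 12 ug/mL and 100 ug/mL, and will most likely again be reported only as a limit.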

Compound 3, half-maximal cytotoxic concentration: > 40 ug/mL
Compound 3 was reported as a limit; the forecaster's own chance of this, stated with the estimate: 70%; middle value at least 1.1-fold (0.05 log units) from the limit.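

Going by these compounds alone, compound 3 gives > 40 ug/mL in this assay, again a limit, and no step among compound 1, compound 2 and compound 3 can be read. The compounds shown leave open where each tolerated concentration actually lies, and whether changing the group on the carbonyl carbon moves it at all.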